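Cyclopropyl for isopropyl at the difluorophenyl end

The source may hold more compounds than are shown below. What is called first, only, known or untested is meant among the compounds shown, and "the series" means these compounds.

Measured compounds:
compound 1, `N#Cc1ccc(Nc2ncc(Cc3c(F)cc(F)cc3F)o2)cc1Cl`, 7000 nM
compound 2, `CC(C)c1cc(F)c(Cc2cnc(Nc3ccc(C#N)c(Cl)c3)o2)c(F)c1`, 5000 nM

Both compounds were tested in an ADME assay on MT2 cells (Homo sapiens) for inhibition; on this read-out higher numbers stand for lower toxicity in this test and lower numbers for higher toxicity in this test. Compound 1 gives 7000 nM in this assay, and compound 2 gives 5000 nM. Among the compounds with values here, the only step between them, a 1.4-fold lower number from compound 1 to compound 2 (0.15 log units; within the scatter), changes an isopropyl for a fluoro on an aromatic carbon and stays within the usual scatter, so the two numbers cannot be told apart.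

Compound 3, `N#Cc1ccc(Nc2ncc(Cc3c(F)cc(C4CC4)cc3F)o2)cc1Cl`, has not yet been measured in this assay. It differs from compound 2 in one place: cyclopropyl in place of isopropyl on an aromatic carbon. Within the data shown here, the only measured step that touches this position, a 1.4-fold lower number from compound 1 to compound 2 (0.15 log units; within the scatter), did not move the number beyond the scatter even though it swapped a single fluoro for a three-carbon group. Exchanging one three-carbon group for another at the same aromatic carbon is therefore expected to give no step beyond the scatter, a 1.1-fold higher number from compound 2 to compound 3 (0.04 log units; within the scatter). Compound 3 is estimated to give 5500 nM in this assay, with a range from 2500 nM to 12000 nM.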

Compound 3, half-maximal cytotoxic concentration in the MT2 assay: 65000 nM
Compound 3: the middle estimate sits 12-fold (1.07 log units) below what was measured; measured number outside the range, above it.
By their numbers in the MT2 assay, from the lowest: compounds 2 and 1 (each within the scatter of the next); then compound 3.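

Within the data shown here, in the MT2 assay, this aromatic carbon turns out to be far more sensitive than the earlier compounds suggested: closing the three carbons into a ring gives a 13-fold higher number from compound 2 to compound 3 (1.11 log units; beyond the scatter), which points to lower toxicity in this test. Isopropyl and cyclopropyl have the same count of heavy atoms, so the number of atoms alone does not set the read-out here, and the ring form also stands clear of the fluoro compound, with a 9.3-fold higher number from compound 1 to compound 3 (0.97 log units; beyond the scatter). Among these compounds, in a physicochemical assay for lipophilicity, measured as octanol-water partition (a lower number here means a more polar compound, a higher number a more lipophilic compound), compound 2 gives 3.7 and compound 3 gives 3.3, so the same exchange from isopropyl to cyclopropyl makes the compound more polar, a shift the earlier compounds could not show: the measured partition coefficient of compound 2, 3.7, and of compound 3, 3.3, a number 0.40 log units lower (beyond the scatter).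

A single pair cannot separate the effect of this drop in lipophilicity on the cytotoxic concentration from that of the ring itself, so the link between the two changes remains unproven. From the compounds shown here alone, it also remains open whether an ethyl, a tert-butyl or a cyclobutyl group on this carbon would give a number close to that of isopropyl or close to that of cyclopropyl, which would show whether the ring is what matters.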